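Swapping the Sulfonyl Aryl Group: From Methoxy to Dichloro

A few compounds are considered here, and "the series" means these few. Any claim that something is new, unique, unknown or untested is made for them only; others in the source may bear on it.

Compound 1 `O=S(=O)(Nc1ccc(-c2nc3ccccc3o2)cc1)c1ccc(Cl)s1`: 31000 nM
Compound 2 `COc1ccc(S(=O)(=O)Nc2ccc(-c3nc4ccccc4o3)cc2)cc1`: > 100000 nM

In an assay on cells for inhibition of HSP60/HSP10 (Homo sapiens), with a stated time of 60 min (on this read-out lower numbers stand for stronger inhibition and higher numbers for weaker inhibition), compound 1 gives 31000 nM. Compound 2 sits at the limit of > 100000 nM in this assay, at which 1 of the 2 values shown sits, a limit of the assay rather than a number. The measured step of an at least 3.2-fold higher number from compound 1 to compound 2 (0.50 log units; beyond the scatter) is the only one that bears on the next change. Compound 3 `O=S(=O)(Nc1ccc(-c2nc3ccccc3o2)cc1)c1ccc(Cl)c(Cl)c1` carries 3,4-dichlorophenyl in place of 4-methoxyphenyl on a sulfonyl sulfur. That step raised the number when a chlorinated ring gave way to the methoxyphenyl; the present change brings a chlorinated ring back, so a lower number is expected. Compound 3 is estimated at 30000 nM (range 8000 nM to 100000 nM), an expected step of an at least 3.3-fold lower number from compound 2 to compound 3 (0.52 log units; beyond the scatter).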

Compound 3, half-maximal inhibitory concentration: 25000 nM
Compound 3: middle estimate off by 1.2-fold (0.08 log units), on the high side; low and high end bracket the measured number.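

Compound 2 gives > 100000 nM, which is a limit of the assay and not a number. Putting 3,4-dichlorophenyl in place of 4-methoxyphenyl on the sulfonyl sulfur still gives a readable step, an at least 4.0-fold lower number from compound 2 to compound 3 (0.60 log units; beyond the scatter), so a chlorinated ring restores measurable inhibition with a benzene-type ring as well as with 5-chlorothiophen-2-yl. The two chlorinated groups cannot be told apart here: a 1.2-fold lower number from compound 1 to compound 3 (0.09 log units; within the scatter).

Still open, from the compounds shown here alone, is how a plain phenyl, a 4-chlorophenyl, or a ring carrying an amine or a carboxylic acid would fare at this sulfonyl sulfur.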